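Amide variation on the azetidine series against glutamate receptor

The source may report more compounds than this note shows. Statements on the series, on what has been measured and on what is new or still open speak of the compounds shown alone.

Compound 2 `O=C(C1CCC(F)(F)CC1)N1CC(c2nc(-c3cccc(Cl)c3)no2)C1` carries 4,4-difluorocyclohexyl on the carbonyl; in an assay on HEK293 cells for negative allosteric modulation of metabotropic glutamate receptor 5 (Homo sapiens), read by FLIPR (a higher number here means a weaker inhibitor, a lower number a stronger inhibitor), compound 2 reaches only the assay limit > 10000 nM. Compound 3 `O=C(C1CCC(F)(F)CC1)N1CC(c2nc(-c3cccc(F)c3)no2)C1` also sits at the limit > 10000 nM. The step that the two limits leave unreadable from compound 2 to compound 3 is thus unreadable; the limit of > 10000 nM in this assay, at which 2 of the 3 values shown sit, marks where both values rest. Compound 1 `Cc1cccc(-c2noc(C3CN(S(=O)(=O)c4ccc(Cl)cc4)C3)n2)c1`, the sulfonyl analogue, gives 1100 nM in this assay. Compound 4 `O=C(N1CCCCC1)N1CC(c2nc(-c3cccc(Cl)c3)no2)C1` differs from compound 2 as follows: piperidin-1-yl in place of 4,4-difluorocyclohexyl on a carbonyl carbon. For the measured compounds named here, no measured step touches this carbonyl substituent, and the starting point of compound 2 is only a limit, so the size of the coming step cannot be read from the data. Compound 4 is expected to give 15000 nM (range 4000 nM to 50000 nM). The estimated step is a step that the limit leaves unreadable from compound 2 to compound 4.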

Compound 4, half-maximal inhibitory concentration: > 10000 nM
Compound 4: no number, only a limit; the forecaster's own chance of this, stated with the estimate: 70%; the middle value is on the limit's open side.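

For the compounds shown here, compound 2 and compound 4 both rest at the assay limit, for compound 4 > 10000 nM, so no step between them can be read. The compounds shown leave open how piperidin-1-yl and 4,4-difluorocyclohexyl on the carbonyl carbon compare in this assay.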